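The source may report more compounds than this note shows. Statements on the series, on what has been measured and on what is new or still open speak of the compounds shown alone.

Measured so far:
- compound 1 `COC(=O)/C=C/C(=O)N[C@@H](C)Cn1ccc(-c2ccc(C#N)c(Cl)c2)n1`, in an ADME assay on PC-3 cells (Homo sapiens) for cytotoxicity, read by CCK-8 assay, with a stated time of 6 days; on this read-out higher numbers stand for weaker inhibition and lower numbers for stronger inhibition: > 30000 nM
- compound 2 `C[C@@H](Cn1ccc(-c2ccc(C#N)c(Cl)c2)n1)Nc1ccncc1`, in this assay: "not determined" (no result reported)

Compound 1 sits at the top of this assay, where the value is a limit rather than a number (the limit of > 30000 nM in this assay, at which 1 of the 2 values shown sits). Compound 2 has no numerical result in this assay, so it cannot be placed against compound 1 on the read-out, and it is only known as the parent of the change that follows.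

Compound 3 `C[C@@H](Cn1ccc(-c2ccc(C#N)c(Cl)c2)n1)Nc1ncnc2nc[nH]c12` differs from compound 2 at one place: a group of 9 heavy atoms (5 carbon, 4 nitrogen; one five-membered aromatic ring with 2 hetero atoms, one six-membered aromatic ring with 2 hetero atoms) in place of a group of 6 heavy atoms (5 carbon, 1 nitrogen; one six-membered aromatic ring with 1 hetero atom), on an amine nitrogen. Among the measured compounds shown here, no measured step exists that would show what such a change does in this assay. For the measured compounds named here, the only measured compound, compound 1, shows a limit and nothing more, so no direction of change can be read from it. Compound 3 is therefore expected to show weak cytotoxicity in this assay, near the top of the measured range, with an estimated value of 20000 nM, between 5000 nM and 30000 nM.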

Compound 3, half-maximal inhibitory concentration: 14100 nM
Estimate against measurement, compound 3: 1.4-fold (0.15 log units) above; measured number inside the range.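

At the amine nitrogen, the group of 9 heavy atoms with its five-membered and six-membered aromatic rings gives the first numerical result in this assay, where compound 3 reads 14100 nM, and the change from the ringless group gives an at least 2.1-fold lower number from compound 1 to compound 3 (0.32 log units; beyond the scatter). Among the compounds shown here, compound 1 reads > 30000 nM, which is a limit and not a number, so the true size of this step remains unknown, and the limit still accounts for part of the values shown: the limit of > 30000 nM in this assay, at which 1 of the 3 values shown sits. The step from the pyridin-4-yl group to the group in compound 3 cannot be read, since compound 2 has no reported result, so the only readable comparison at this position is the one against the ringless group.

The compounds shown leave open whether the five-membered ring or the six-membered ring of the entering group accounts for the step, since the two occur only together here. They also leave open how a phenyl group, a simple alkyl chain or a carboxylic acid on the amine nitrogen would read in this assay.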